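The source may hold more compounds than are shown below. What is called first, only, known or untested is meant among the compounds shown, and "the series" means these compounds.

In a functional assay on A549 cells (Homo sapiens) for antiproliferative activity, read by MTT assay, with a stated time of 48 h (a higher number here means a weaker inhibitor, a lower number a stronger inhibitor), compound 1 (`COc1ccc(Oc2nc3ccccc3cc2/C=N/NC(=O)Cn2c([N+](=O)[O-])cnc2C)cc1`) gives 920 nM, compound 2 (`Cc1ncc([N+](=O)[O-])n1CC(=O)N/N=C/c1cc2ccccc2nc1Oc1ccc(Cl)cc1`) gives 9030 nM and compound 3 (`Cc1ccc2nc(Oc3ccccc3)c(/C=N/NC(=O)Cn3c([N+](=O)[O-])cnc3C)cc2c1`) gives 7180 nM. Compound 3 thus lies within the scatter of compound 2 and well above compound 1. Compound 4 (`Cc1ccc2nc(Oc3ccc(F)cc3)c(/C=N/NC(=O)Cn3c([N+](=O)[O-])cnc3C)cc2c1`) carries fluoro in place of hydrogen on an aromatic carbon, para to a large group: fluoro in place of hydrogen on an aromatic carbon. Among the measured compounds shown here, the only measured step that bears on this is a 9.8-fold higher number from compound 1 to compound 2 (0.99 log units; beyond the scatter), chloro in place of methoxy, which is a modest step but exchanges a different pair of groups. For the measured compounds named here, no measured step replaces hydrogen with a halogen, so no shift beyond the scatter is expected. The expected change is a 1.2-fold lower number from compound 3 to compound 4 (0.08 log units; within the scatter). Compound 4 is estimated at 6000 nM, with an expected range of 2300 nM to 13000 nM.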

Compound 4, half-maximal inhibitory concentration: 190 nM
For compound 4 the middle estimate is 32-fold (1.50 log units) above the measured one; the whole stated range lies above it.
By their numbers in this assay, from the lowest: compound 4; then compound 1; then compounds 3 and 2 (each within the scatter of the next).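

Fluoro in place of hydrogen, on an aromatic carbon para to a large group, gives a 38-fold lower number from compound 3 to compound 4 (1.58 log units; beyond the scatter) in this assay and so shows that this single atom can shift the result far beyond the scatter. The earlier compounds shown here offered only an exchange of chloro for methoxy, with no step away from hydrogen on this ring. Nothing measured here explains this shift. From the compounds shown here alone, whether chloro or methoxy in place of that hydrogen would act like fluoro on the core of compound 3 remains open, as does the effect of an amine there.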